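Bromo to methylsulfanyl on the cinnamamide aryl ring

This account rests on a few compounds, and the source may have more. Where it says the series, first, only, none or still open, it means among the compounds named here.

Measured compounds:
compound 1, `CCCc1cc(NC2CCC2)c2cc(NC(=O)/C=C/c3ccc(C(F)(F)F)cc3)ccc2n1`: 18 nM
compound 2, `CCCc1cc(N)c2cc(NC(=O)/C=C/c3ccc(Br)cc3)ccc2n1`: 4 nM

Of the compounds shown here, two have been tested in an assay on isolated protein for displacement of a labelled ligand from melanin-concentrating hormone receptor 1 (Homo sapiens); on this read-out higher numbers stand for weaker inhibition and lower numbers for stronger inhibition. In this assay compound 1 gives 18 nM, while compound 2 gives 4 nM, the lower of the two numbers; compound 1 stands a good way higher, beyond the scatter. Within the data shown here, the two compounds differ in more than one place, so no single step between them can be drawn.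

Compound 3, `CCCc1cc(N)c2cc(NC(=O)/C=C/c3ccc(SC)cc3)ccc2n1`, has not yet been measured. It differs from compound 2 in one place: methylsulfanyl in place of bromo on an aromatic carbon. Nothing measured here speaks directly to this exchange, so the expectation rests on compound 2 alone. The step of a 1.5-fold higher number from compound 2 to compound 3 (0.18 log units; within the scatter) is expected to be small, within the scatter, in either direction. Compound 3 is therefore estimated at 6 nM, with a range from 2 nM to 18 nM.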

Compound 3, half-maximal inhibitory concentration: 9 nM
Compound 3: the middle estimate sits 1.5-fold (0.18 log units) below what was measured; the range from low to high includes it.
By their numbers in this assay, from the lowest: compound 2; then compounds 3 and 1 (each within the scatter of the next).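

In this assay, among these compounds, the exchange of bromo for methylsulfanyl gives a 2.3-fold higher number from compound 2 to compound 3 (0.35 log units; beyond the scatter) and is the first change at a single place that can be read. It shows that this aromatic carbon, para to a large group, responds to the exchange only modestly: with methylsulfanyl bringing 2 heavy atoms in place of 1, compound 3 still gives 9 nM in this assay. No measurement at hand bears on why the number moves.

The compounds shown leave open whether a methoxy group, a nitrile or a longer alkylsulfanyl chain at this carbon would stay as close to compound 2. They also leave open whether the same exchange would give a step of similar size on the core of compound 1.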